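Shrinking the urea substituent on an aziridine nitrile

A few compounds are considered here, and "the series" means these few. Any claim that something is new, unique, unknown or untested is made for them only; others in the source may bear on it.

Measured so far:
Compound 1 `CC(C)(C)NC(=O)N1CC1C#N`: 457000 nM
Compound 2 `CCNC(=O)N1CC1C#N`: 14000 nM

The two compounds measured share one core, an aziridine carrying a nitrile, joined through a urea to a single alkyl group. In a functional assay on L1210 cells (Mus musculus) for inhibition, read by MTT assay (a lower number here means a stronger inhibitor, a higher number a weaker inhibitor), compound 1 gives 457000 nM, while compound 2 gives 14000 nM. Compound 2 therefore stands lowest of the two numbers; its nearest neighbour is compound 1, separated by the step of a 33-fold lower number from compound 1 to compound 2 (1.51 log units; beyond the scatter), which comes from an ethyl in place of a tert-butyl on the amide-type nitrogen.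

Compound 3 `CNC(=O)N1CC1C#N` has not yet been measured in this assay. It differs from compound 2 by one change: hydrogen in place of methyl on a saturated chain carbon bound to an amide-type nitrogen, so the ethyl becomes a methyl. Among the compounds with values here, only one measured step bears on this, the large drop a 33-fold lower number from compound 1 to compound 2 (1.51 log units; beyond the scatter) seen when the alkyl group was made smaller. The change to compound 3 removes far less than that earlier step did, so a smaller move in the same direction is expected, though a result within the scatter would not be surprising. Compound 3 is therefore estimated at 6000 nM, with a range of 1500 nM to 25000 nM, corresponding to an expected step of a 2.3-fold lower number from compound 2 to compound 3 (0.37 log units; beyond the scatter).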

Compound 3, half-maximal inhibitory concentration: 21000 nM
The estimate for compound 3 lay 3.5-fold (0.54 log units) below the measured number; measured number inside the range.
By their numbers in this assay, from the lowest: compounds 2 and 3 (each within the scatter of the next); then compound 1.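

In this assay, trimming ethyl to methyl on the urea gives a 1.5-fold higher number from compound 2 to compound 3 (0.18 log units; within the scatter) and so falls within the usual scatter: at this position, compound 2 and compound 3 cannot be told apart, and removing this one carbon from the chain has no measurable effect. The large move seen earlier is also not specific to ethyl, as methyl in place of tert-butyl gives a 22-fold lower number from compound 1 to compound 3 (1.34 log units; beyond the scatter) and stands just as clear of compound 1, so among these three compounds the only steps beyond the scatter are the two that leave tert-butyl. No measurement available here explains why tert-butyl stands apart from the two smaller groups.

The compounds shown leave open where between ethyl and tert-butyl the number begins to climb, which isopropyl or a longer chain such as n-butyl on the same nitrogen could help to locate. They also leave open how a ring such as phenyl or cyclohexyl would read at this position on the shared core.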